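The source may hold more compounds than are shown below. What is called first, only, known or untested is meant among the compounds shown, and "the series" means these compounds.

Measured so far:
compound 1 `CNS(=O)(=O)c1ccc(-c2cnc(N)c(-c3ccc(OC)nc3)c2)cc1` — 9.6 mL.min-1.g-1
compound 2 `COc1ccc(-c2cc(-c3ccc4cnn(C)c4c3)cnc2N)cn1` — 12 mL.min-1.g-1

In an in vitro ADME assay on microsomes from liver (Homo sapiens) for metabolic stability (a lower number here means slower removal, a higher number faster removal of the compound), compound 1 gives 9.6 mL.min-1.g-1. Compound 2 gives 12 mL.min-1.g-1, and the gap between the two numbers lies within the scatter, so the pair reads alike. Compound 3 `COc1ccc(-c2cc(-c3ccc(C(=O)O)cc3)cnc2N)cn1` is not yet measured in this assay. It differs from compound 1 in one place: carboxy in place of methylsulfamoyl on an aromatic carbon. Among the compounds with values here, no measured pair shows this change, so its size here is open. A downward step is expected, a 1.9-fold lower number from compound 1 to compound 3 (0.28 log units; within the scatter), of modest size. Compound 3 is expected to give 5 mL.min-1.g-1 in this assay, within 2 mL.min-1.g-1 to 12 mL.min-1.g-1.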

Compound 3, intrinsic clearance in microsomes: < 7 mL.min-1.g-1
Compound 3 was reported as a limit; the forecaster's own chance of this, stated with the estimate: 10%; the middle value does not contradict the limit.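

In this assay compound 3 is reported as a limit and not as a number: the limit of < 7 mL.min-1.g-1 in this assay, at which 1 of the 3 values shown sits.

Carboxy in place of methylsulfamoyl on an aromatic carbon, para to a large group, gives an at least 1.3-fold lower number from compound 1 to compound 3 (0.13 log units; that floor lies within the scatter). This position therefore tolerates the exchange with no rise in the read-out, though the floor of the step does not show a real drop.

On these data alone, how far the true number of compound 3 lies from compound 1 stays open. So does the reading for an amine or a nitrile on this same carbon of the shared core.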